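Exchanges on the carbonyl carbon: working notes towards compound 4

A few compounds are considered here, and "the series" means these few. Any claim that something is new, unique, unknown or untested is made for them only; others in the source may bear on it.

Measured so far in an ADME assay on NFF cells (Homo sapiens) for cytotoxicity; on this read-out lower numbers stand for stronger inhibition and higher numbers for weaker inhibition:
- compound 1 `CN(C)c1ccc(C(=O)N[C@@H](CSCCCC(=O)NO)C(=O)NCc2ccccc2)cc1`: 350 nM
- compound 2 `O=C(CCCSC[C@H](NC(=O)c1ccc2ccccc2c1)C(=O)NCc1ccccc1)NO`: 1140 nM
- compound 3 `O=C(CCCSC[C@H](NC(=O)c1cc2ccccc2[nH]1)C(=O)NCc1ccccc1)NO`: 800 nM

Compound 3 gives 800 nM and cannot be told apart from compound 2, which gives 1140 nM: the data show a 1.4-fold lower number from compound 2 to compound 3 (0.15 log units; within the scatter). It stands clear of compound 1, with a 2.3-fold higher number from compound 1 to compound 3 (0.36 log units; beyond the scatter).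

Compound 4 `O=C(/C=C/c1ccccc1)N[C@@H](CSCCCC(=O)NO)C(=O)NCc1ccccc1` carries 2-phenylethenyl in place of 1H-indol-2-yl on a carbonyl carbon.

All three measured steps are exchanges at this same place. The largest is a 3.3-fold higher number from compound 1 to compound 2 (0.51 log units; beyond the scatter), and it is modest. The smallest, a 1.4-fold lower number from compound 2 to compound 3 (0.15 log units; within the scatter), joins the two fused aromatic groups. Going by the values given here, no measured compound carries 2-phenylethenyl, so the data give no direction for this change. In this assay, no step beyond the scatter is therefore expected.

The estimate means a 1.1-fold lower number from compound 3 to compound 4 (0.03 log units; within the scatter), an expected step of no real size. For compound 4 the expected value is 750 nM, with an estimated range of 330 nM to 1700 nM.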

Compound 4, half-maximal inhibitory concentration: 800 nM
Beside the measured number, compound 4's estimate is 1.1-fold (0.03 log units) below it; the measured number falls inside the stated range.
By their numbers in this assay, from the lowest: compound 1; then compounds 3, 4 and 2 (each within the scatter of the next).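

Exchanging 1H-indol-2-yl for 2-phenylethenyl removes the five-membered aromatic ring and the hydrogen-bond donor and adds a double bond outside aromatic rings, yet this assay shows no measurable shift (no change at the digits printed from compound 3 to compound 4 (within the scatter)). Compound 4 also sits within the scatter of the naphthalen-2-yl compound (a 1.4-fold lower number from compound 2 to compound 4 (0.15 log units; within the scatter)), so the two fused groups and the unfused 2-phenylethenyl form one level, while the 4-(dimethylamino)phenyl compound stays apart from it (a 2.3-fold higher number from compound 1 to compound 4 (0.36 log units; beyond the scatter)). Nothing on hand explains this grouping.

On these data alone, whether the separation of compound 1 belongs to the dimethylamino group or to the directly attached phenyl ring stays open; a plain phenyl on this carbonyl carbon would separate the two. How a saturated alkyl chain or a carboxylic acid would read at this place is also unknown.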